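The source may report more compounds than this note shows. Statements on the series, on what has been measured and on what is new or still open speak of the compounds shown alone.

Measured in a functional assay on HCT-15 cells (Homo sapiens) for antiproliferative activity, read by XTT assay; on this read-out higher numbers stand for weaker inhibition and lower numbers for stronger inhibition:
- Compound 1 `CC(C)CCOc1cccc2occ(Cc3coc4ccccc4c3=O)c(=O)c12`: > 10000 nM, a limit, not a number
- Compound 2 `COc1ccc2c(=O)c(Cc3coc4cccc(OCC5CCCCC5)c4c3=O)coc2c1`: 1450 nM

Compound 1 stands at the limit of > 10000 nM in this assay, at which 1 of the 2 values shown sits. Compound 3 `COc1cccc2occ(Cc3coc4ccccc4c3=O)c(=O)c12` keeps the core of compound 1 but has hydrogen in place of isobutyl on a saturated chain carbon bound to an oxygen on an aromatic ring, which turns isopentyloxy into methoxy. For the measured compounds named here, no measured step shows what this change does, so only a small move towards stronger inhibition is expected, an at least 1.2-fold lower number from compound 1 to compound 3 (0.09 log units; that floor lies within the scatter). For compound 3 the estimated value is 8000 nM, with a range from 2500 nM to 25000 nM.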

Compound 3, half-maximal inhibitory concentration: 3430 nM
Estimate against measurement, compound 3: 2.3-fold (0.37 log units) above; the measured number falls inside the stated range.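

Cutting isopentyloxy back to methoxy gives an at least 2.9-fold lower number from compound 1 to compound 3 (0.46 log units; beyond the scatter) in this assay. For the compounds shown here, this is the first step read at this place, and it shows that the longer isopentyloxy group is not needed for inhibition of these cells, with the shorter methoxy group doing better. The size of the step is only a floor, since compound 1 stands at a limit and not at a number: the limit of > 10000 nM in this assay, at which 1 of the 3 values shown sits.

Going by these compounds, what an ethoxy group or a free hydroxyl at this place would give stays open. On these data alone, whether inhibition falls steadily with chain length or drops suddenly also stays open.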